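Allylamino to cyclobutylamino on the dichloro core

The compounds below may be only part of what the source reports. "The series", "measured", "known", "first", "only" and "open" are said of these compounds alone.

Measured so far in a functional assay (aorta) with Rattus norvegicus as the target, with a stated time of 90 min, at 37 degrees C; a lower number here means that less compound is needed, a higher number that more compound is needed for the effect:
- compound 1 `CC(C)NC1=NS(=O)(=O)c2cc(Cl)ccc2N1` gives 36300 nM
- compound 2 `C=CCNC1=Nc2cc(Cl)c(Cl)cc2S(=O)(=O)N1` gives 1200 nM

Compound 2 holds the lowest of the two numbers in this assay; compound 1 sits at a much higher number, and the gap between the two lies beyond the scatter. Among the compounds with values here, the two differ in more than one place, so no single step connects them; only the two values themselves can be compared.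

Compound 3 `O=S1(=O)NC(NC2CCC2)=Nc2cc(Cl)c(Cl)cc21` differs from compound 2 in one place: cyclobutyl in place of allyl on an amine nitrogen. Within the data shown here, no step of this kind between measured compounds is available to calibrate it. With a ring of similar size replacing the allyl chain on the same nitrogen, the step from compound 2 to compound 3 in this assay is expected to be small, a 1.3-fold higher number from compound 2 to compound 3 (0.10 log units; within the scatter), with no change beyond the scatter. Compound 3 is therefore estimated at 1500 nM, with a range of 500 nM to 5000 nM.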

Compound 3, half-maximal effective concentration: 12600 nM
Beside the measured number, compound 3's estimate is 8.4-fold (0.92 log units) below it; the whole stated range lies below it.
By their numbers in this assay, from the lowest: compound 2; then compound 3; then compound 1.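

Within the data shown here, this is the first single-place step: in this assay, cyclobutyl in place of allyl on an amine nitrogen gives an 11-fold higher number from compound 2 to compound 3 (1.02 log units; beyond the scatter) on the shared core. The number therefore responds strongly to the group on this nitrogen, even in an all-carbon exchange where no hydrogen-bond donors or acceptors enter or leave. No measurement given here accounts for the size of this step.

The step combines two changes, loss of the double bond and gain of the four-membered ring, and the compounds shown cannot separate them. As far as these compounds go, it remains open whether an open saturated chain such as propyl, or a cyclopropyl group, on the same nitrogen would give a number closer to that of compound 2 or compound 3.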